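Shortening a Side Chain on a Shared Aryl Keto-Acid Core

The source may hold more compounds than are shown below. What is called first, only, known or untested is meant among the compounds shown, and "the series" means these compounds.

Measured so far in a functional assay on LS174T cells (Homo sapiens) for inhibition, read by MTT assay, with a stated time of 72 h; a lower number here means a stronger inhibitor, a higher number a weaker inhibitor:
compound 1, `CC(C)c1cc(C(C)C)c(C(=O)/C=C/C(=O)O)c(C(C)C)c1`, gives 8280 nM
compound 2, `CC(C)(C)c1ccc(C(=O)/C=C/C(=O)O)cc1`, gives 8740 nM
compound 3, `CCCCCCCCCCCCc1ccc(C(=O)/C=C/C(=O)O)cc1`, gives 7850 nM

The three compounds share a core and differ only in the groups attached to its ring. Their numbers in this assay lie within the scatter of one another, so compound 2 stands level with compound 1 and compound 3; none of the three can be called stronger or weaker.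

The next compound, compound 4, `CC(C)c1ccc(C(=O)/C=C/C(=O)O)cc1`, is reached from compound 2 by one change: hydrogen in place of methyl on a saturated chain carbon bound to an aromatic carbon and two saturated chain carbons. Since widely different groups on this ring have left the number essentially unchanged, no step beyond the scatter is expected: the expected step from compound 2 to compound 4 is a 1.0-fold lower number from compound 2 to compound 4 (0.01 log units; within the scatter). Compound 4 is therefore estimated at 8500 nM, with a range from 4000 nM to 18000 nM.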

Compound 4, half-maximal inhibitory concentration: 25700 nM
Compound 4: the middle estimate sits 3.0-fold (0.48 log units) below what was measured; measured number outside the range, above it.
By their numbers in this assay, from the lowest: compounds 3, 1 and 2 (each within the scatter of the next); then compound 4.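

In this assay, cutting tert-butyl back to isopropyl gives a 2.9-fold higher number from compound 2 to compound 4 (0.47 log units; beyond the scatter), so compound 4 is the weaker inhibitor of the pair. For the compounds shown here, this is the first sign that the group at this place can move the number, since the earlier compounds stood level despite their different groups. No measurement offered here bears on why this single methyl matters.

The compounds shown leave open whether an ethyl or a methyl group in place of tert-butyl would raise the number further. They also leave open whether a cyclopropyl group there would keep it level with compound 2.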